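The source may report more compounds than this note shows. Statements on the series, on what has been measured and on what is new or still open speak of the compounds shown alone.

Two compounds share one core and differ only in the benzyl group on a saturated chain carbon bound to an amide-type nitrogen in a ring. Compound 1 `COc1ccc(N2C(=O)N(Cc3c(F)cc(F)cc3F)c3ccccc3S2(=O)=O)cc1OC` carries a fluoro there, compound 2 `COc1cc(F)c(CN2C(=O)N(c3ccc(OC)c(OC)c3)S(=O)(=O)c3ccccc32)c(F)c1` a methoxy. In an assay on isolated protein for displacement of a labelled ligand from Orexin/Hypocretin receptor type 1 (Homo sapiens), with a stated time of 90 min (a higher number here means a weaker inhibitor, a lower number a stronger inhibitor), compound 1 gives 50.1 nM, and compound 2 gives 2 nM. The step of a 25-fold lower number from compound 1 to compound 2 (1.40 log units; beyond the scatter) is the only one measured so far, and it leaves compound 2 with the lower of the two numbers.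

Compound 3 `COc1ccc(N2C(=O)N(Cc3ccccc3F)c3ccccc3S2(=O)=O)cc1OC` has not been measured. It differs from compound 2 in that (2-fluorophenyl in place of 2,6-difluoro-4-methoxyphenyl on a saturated chain carbon bound to an amide-type nitrogen in a ring); the same difference, cut one bond further out, reads 2,6-difluoro-4-methoxybenzyl to 2-fluorobenzyl. For the measured compounds named here, the entering group has no methoxy, and the single measured step, from compound 1 to compound 2, shows that methoxy in place of fluoro went with a large drop in the number. Going by the values given here, in compound 3 the methoxy is absent, and one fluoro is absent as well, a change on which no measured step gives guidance. A rise beyond the scatter is therefore expected, of about a 30-fold higher number from compound 2 to compound 3 (1.48 log units; beyond the scatter). Compound 3 is expected to give 60 nM in this assay, within 15 nM to 250 nM.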

Compound 3, inhibition constant: 316 nM
Beside the measured number, compound 3's estimate is 5.3-fold (0.72 log units) below it; measured number outside the range, above it.
By their numbers in this assay, from the lowest: compound 2; then compound 1; then compound 3.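

The fluoro groups on this benzyl group matter in their own right: with no methoxy involved, going from 2,4,6-trifluorophenyl to 2-fluorophenyl gives a 6.3-fold higher number from compound 1 to compound 3 (0.80 log units; beyond the scatter) in this assay. For the compounds shown here, the earlier compounds spoke only to swapping one fluoro for a methoxy, whereas the full change from 2,6-difluoro-4-methoxyphenyl to 2-fluorophenyl gives a 160-fold higher number from compound 2 to compound 3 (2.20 log units; beyond the scatter) and spans both kinds of loss, so the methoxy is not the only part of this group tied to the number. Among these compounds, the number rises in order from the methoxy-bearing benzyl group through the trifluoro one to the 2-fluorobenzyl group, but nothing shown explains why the binding numbers move this way.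

The compounds shown leave open how the change divides among the individual fluoro groups, as both of the fluoro groups that differ between compound 1 and compound 3 change together. They also leave open whether the gain stays with the methoxy alone or extends to an ethoxy, a hydroxy or a dimethylamino group at the same place on the ring.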